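Furan and thiophene series: ester swap at the saturated-ring carbon

The source may hold more compounds than are shown below. What is called first, only, known or untested is meant among the compounds shown, and "the series" means these compounds.

Measured compounds and values in an assay on membranes from HeLa cells for displacement of a labelled ligand from adenosine receptor A3 (Homo sapiens), read by scintillation counting, with a stated time of 180 min, tested at 1 uM; on this read-out lower numbers stand for less inhibition and higher numbers for more inhibition at the one concentration tested (going by the name of the read-out):
compound 1 `CC1=C(C(=O)OCc2ccccc2)C(c2ccco2)NC(=O)N1`, 3%
compound 2 `CC1=C(C(=O)OCc2ccccc2)C(c2ccoc2)NC(=O)N1`, 1%
compound 3 `CC1=C(C(=O)OC(C)(C)C)C(c2ccsc2)NC(=O)N1`, 1%

Compound 3 stands level with compound 2 at the digits reported, and the two together are the lowest of the three numbers; compound 1 sits a number 2 percentage points lower from compound 1 to compound 2 (within the scatter) apart from compound 2, which is within the scatter. All three measured compounds therefore give essentially no inhibition in this assay.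

Compound 4 `CC1=C(C(=O)OCc2ccccc2)C(c2ccsc2)NC(=O)N1` is not yet measured. It differs from compound 3 in one place: benzyl in place of tert-butyl on an oxygen next to a carbonyl group. Among the compounds with values here, no measured pair isolates this change, so nothing on record shows how a benzyl in place of a tert-butyl on an oxygen next to a carbonyl group moves the read-out. What is on record is that compounds 1 and 2, which carry the benzyl, and compound 3, which carries the tert-butyl, all sit near the floor of the read-out, so the step of a number 1 percentage points higher from compound 3 to compound 4 (within the scatter) is expected to be nothing beyond the scatter. Compound 4 is estimated at 2%, with a range from -6% to 10%.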

Compound 4, a percentage reported as inhibition, at one concentration (the size of the read-out at that concentration, not a potency): 25%
Compound 4: the middle estimate sits 23 percentage points below what was measured; measured number outside the range, above it.
By their numbers in this assay, from the lowest: compounds 2, 3 and 1 (each within the scatter of the next); then compound 4.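

In this assay the ester oxygen position is not silent: with thiophen-3-yl held on the saturated ring carbon, benzyl in place of tert-butyl gives a number 24 percentage points higher from compound 3 to compound 4 (beyond the scatter) in this series. The saturated ring carbon also responds with benzyl held, since thiophen-3-yl in place of furan-3-yl gives a number 24 percentage points higher from compound 2 to compound 4 (beyond the scatter) and thiophen-3-yl in place of furan-2-yl gives a number 22 percentage points higher from compound 1 to compound 4 (beyond the scatter) as the second comparison. Among these four compounds, only benzyl and thiophen-3-yl together lift the read-out clear of the others, and nothing on record explains this.

The compounds shown leave open whether thiophen-2-yl, or a phenyl ring, on the saturated ring carbon would serve as thiophen-3-yl does. They also leave open how a longer chain, a substituted benzyl or an amide in place of the ester would fare.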